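From 2,5-difluorophenyl to 2,3-dichlorophenyl on compound 3

This account rests on a few compounds, and the source may have more. Where it says the series, first, only, none or still open, it means among the compounds named here.

In an ADME assay on MT4 cells (Homo sapiens) for cytotoxicity, read by MTT assay (on this read-out lower numbers stand for higher toxicity in this test and higher numbers for lower toxicity in this test), three compounds sharing one core have been tested so far. Compound 1 `Cc1ccc(N(C(=O)c2ccccc2C)C(=S)OCCN2C(=O)c3ccccc3C2=O)cc1` gives > 100000 nM, which is a limit of the assay and not a number. Compound 2 `Cc1ccc(N(C(=O)c2ccc(F)cc2F)C(=S)OCCN2C(=O)c3ccccc3C2=O)cc1` gives 20000 nM. Compound 3 `Cc1ccc(N(C(=O)c2cc(F)ccc2F)C(=S)OCCN2C(=O)c3ccccc3C2=O)cc1` gives 62000 nM, the higher of the two true numbers, so it is the less toxic of that pair in this test.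

Compound 4 `Cc1ccc(N(C(=O)c2cccc(Cl)c2Cl)C(=S)OCCN2C(=O)c3ccccc3C2=O)cc1` is the next to be considered. It carries 2,3-dichlorophenyl in place of 2,5-difluorophenyl on a carbonyl carbon.

For the measured compounds named here, three measured steps concern this same group: an at least 5.0-fold lower number from compound 1 to compound 2 (0.69 log units; beyond the scatter), an at least 1.6-fold lower number from compound 1 to compound 3 (0.20 log units; that floor lies within the scatter) and a 3.1-fold higher number from compound 2 to compound 3 (0.49 log units; beyond the scatter). They show that changing this group alone can shift the number modestly. None of the tested compounds carries chlorine, so these steps guide the likely size of the change better than its direction.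

Compound 3 sits at the upper end of the true numbers, with compound 2 at 20000 nM, so a slight fall is expected rather than a rise. The expected change is a 1.4-fold lower number from compound 3 to compound 4 (0.14 log units; within the scatter), which would not clearly exceed the scatter. For compound 4 the estimated value is 45000 nM, with an expected range of 15000 nM to 100000 nM.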

Compound 4, half-maximal cytotoxic concentration: 35000 nM
Compound 4: the middle estimate sits 1.3-fold (0.11 log units) above what was measured; low and high end bracket the measured number.
By their numbers in this assay, from the lowest: compounds 2, 4 and 3 (each within the scatter of the next, the first and the last beyond it). At a limit, above all of these: compound 1.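

Two chlorines on this ring give a result that cannot be separated from either difluorophenyl compound in this assay: there is a 1.8-fold lower number from compound 3 to compound 4 (0.25 log units; within the scatter), and a 1.8-fold higher number from compound 2 to compound 4 (0.24 log units; within the scatter), even though the two fluorine compounds themselves are separated by a 3.1-fold higher number from compound 2 to compound 3 (0.49 log units; beyond the scatter). Compound 1 gives > 100000 nM, which is a limit of the assay and not a number. The 2,3-dichlorophenyl group is nevertheless clearly set apart from 2-methylphenyl, with an at least 2.8-fold lower number from compound 1 to compound 4 (0.45 log units; beyond the scatter), a pattern shared by compound 2 but not shown by compound 3, and this size is only a floor because compound 1 sits at a limit: the limit of > 100000 nM in this assay, at which 1 of the 4 values shown sits.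

On these data alone, it remains open whether a single chlorine on the phenyl ring would read like two, and whether a phenyl ring carrying an amine or a carboxylic acid on the same carbonyl carbon would stay close to these numbers. All four compounds share the rest of the core, so they say nothing about how a change elsewhere, such as a longer chain in place of the one bearing the phthalimide-free end of the shared core, would read in this assay.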